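The source may report more compounds than this note shows. Statements on the series, on what has been measured and on what is new or still open speak of the compounds shown alone.

The series concerns chalcone-like compounds tested in a functional assay on HeLa cells (Homo sapiens) for inhibition, read by MTT assay, with a stated time of 72 h; on this read-out higher numbers stand for weaker inhibition and lower numbers for stronger inhibition. Compound 1 `COc1ccc(/C=C/C(=O)c2c(OC)cc(O)c(CC=C(C)C)c2O)cc1OC` carries a 3-methylbut-2-en-1-yl group on an aromatic carbon; in this assay compound 1 gives 27700 nM. Compound 3 `COc1ccc(/C=C/C(=O)c2c(O)cc(O)cc2OC)cc1OC` is its counterpart without that group, and in this assay compound 3 gives 49500 nM. The change between them, (hydrogen in place of 3-methylbut-2-en-1-yl on an aromatic carbon), produced a 1.8-fold higher number from compound 1 to compound 3 (0.25 log units; within the scatter).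

Compound 2 `COc1cc(O)c(CC=C(C)C)c(O)c1C(=O)/C=C/c1cccc([N+](=O)[O-])c1` shares the same substituted core but bears a different aryl part on the other end of the enone; in this assay compound 2 gives 16500 nM. The difference between the core of compound 1 and the core of compound 2 is not broken down here, so only their two values can be compared: compound 2 stands at a lower number than compound 1, though the gap is within the scatter, and at a lower number than compound 3 by a margin beyond it.

Compound 4 `COc1cc(O)cc(O)c1C(=O)/C=C/c1cccc([N+](=O)[O-])c1` is to compound 2 what compound 3 is to compound 1: the change is hydrogen in place of 3-methylbut-2-en-1-yl on an aromatic carbon, and its place line reads the same word for word as the earlier one, so it is the same change. Because the earlier step of a 1.8-fold higher number from compound 1 to compound 3 (0.25 log units; within the scatter) was small, a comparable step a 1.8-fold higher number from compound 2 to compound 4 (0.26 log units; within the scatter) is expected, resting on compound 2 at 16500 nM. Compound 4 is therefore estimated at 30000 nM, with a likely range from 15000 nM to 60000 nM.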

Compound 4, half-maximal inhibitory concentration: 15500 nM
Estimate against measurement, compound 4: 1.9-fold (0.29 log units) above; measured number inside the range.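

Putting hydrogen in place of the 3-methylbut-2-en-1-yl group on the core of compound 2 gives, in this assay, a 1.1-fold lower number from compound 2 to compound 4 (0.03 log units; within the scatter), so the step is small on this core as well. Set beside the earlier step, the change carries from one core to the other with no difference that can be told from the scatter: the same change on two cores in this assay, a 1.8-fold higher number (0.25 log units; within the scatter) from compound 1 to compound 3 and a 1.1-fold lower number (0.03 log units; within the scatter) from compound 2 to compound 4, 1.9-fold (0.28 log units) apart, within the scatter of two such steps. Among the compounds shown here, this shows only that on these two pairs, whose aryl parts differ, neither step nor the gap between them exceeds the scatter; it does not show that the two steps are identical, that the 3-methylbut-2-en-1-yl group has no effect on any other core, or that the result would hold outside this one cell assay.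

In the compounds shown, that aromatic carbon carries only the 3-methylbut-2-en-1-yl group or hydrogen, so it remains open how a shorter chain such as methyl, a longer chain such as geranyl, or an amine would fare there. From the compounds shown here alone, it also remains open whether the step stays this small with other aryl parts, for example one bearing a carboxylic acid.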